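The source may report more compounds than this note shows. Statements on the series, on what has been measured and on what is new or still open speak of the compounds shown alone.

Of the compounds shown here, three have so far been tested in an assay on isolated protein for inhibition of LIM domain kinase 1 (Homo sapiens), read by Kinase-Glo, with a stated time of 60 min; on this read-out higher numbers stand for weaker inhibition and lower numbers for stronger inhibition. Compound 1 `CN(C)C(=O)c1sc2ncccc2c1N` gives only a limit of the assay, > 100000 nM. Compound 2 `CCOC(=O)c1sc2ccccc2c1N` likewise gives only a limit, > 100000 nM. Compound 3 `NC(=O)c1sc2nc(-c3ccc4c(c3)OCCO4)cc(C(F)(F)F)c2c1N` gives a number, 1300 nM. Compound 2 therefore stands at the limit of > 100000 nM in this assay, at which 2 of the 3 values shown sit, with no inhibition recorded within the tested range.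

Compound 4 `NC(=O)c1sc2ccccc2c1N` differs from compound 2 in one place: amino in place of ethoxy on a carbonyl carbon. Within the data shown here, no measured pair shows this change on its own. Compound 3 carries the same carbamoyl group, yet also further groups that compound 4 lacks. Compound 1, which also lacks those groups, gives only a limit. The estimate therefore means a step of an at least 1.1-fold lower number from compound 2 to compound 4 (0.04 log units; that floor lies within the scatter), expected to remain within the scatter. Compound 4 is expected near 90000 nM, most likely between 25000 nM and 300000 nM.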

Compound 4, half-maximal inhibitory concentration: 33000 nM
Beside the measured number, compound 4's estimate is 2.7-fold (0.44 log units) above it; measured number inside the range.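

Putting amino in place of ethoxy on a carbonyl carbon gives an at least 3.0-fold lower number from compound 2 to compound 4 (0.48 log units; beyond the scatter) and so shows that the group at this position can change the read-out, even on the small core. The true step may be larger, because compound 2 gives only a limit of the assay: the limit of > 100000 nM in this assay, at which 2 of the 4 values shown sit.

As far as these compounds go, whether a methylamino group, a carboxylic acid or a longer ester at the same place would give a lower or a higher number remains open. Also open, from the compounds shown here alone, is whether this change gives a similar step on other cores.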